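The source may hold more compounds than are shown below. What is called first, only, known or untested is meant among the compounds shown, and "the series" means these compounds.

The measured compounds in an ADME assay on microsomes from liver (Homo sapiens) for metabolic stability, read by LC-MS, using NADPH, tested at 3 uM (a lower number here means that the compound disappears faster, a higher number that the compound lasts longer), are these:

Compound 1 `N#CC(C#N)C(c1ccccc1)c1c(-c2ccccc2)[nH]c2ccccc12` gives 0.437 h
Compound 2 `N#CCC(c1ccccc1)c1c(-c2ccccc2)[nH]c2cc(Cl)ccc12` gives 0.72 h
Compound 3 `Cc1ccc2c(C(c3cccs3)C(C#N)C#N)c(-c3ccccc3)[nH]c2c1` gives 0.52 h

Compound 1 stands within the scatter of both compound 2 and compound 3, so these numbers do not set it apart from either. Compound 4 `OC(C(c1ccccc1)c1c(-c2ccccc2)[nH]c2ccccc12)C(F)(F)F` has 2,2,2-trifluoro-1-hydroxyethyl in place of dicyanomethyl on a saturated chain carbon bound to two aromatic carbons. For the measured compounds named here, no two measured compounds differ in only one place, so the data hold no direct measure of such a change.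

Compound 2 (0.72 h) and compound 3 (0.52 h) differ from compound 1 in structure yet stay within the scatter of it, so only a small upward step, none beyond the scatter, is expected in this assay. The estimated change is a 1.3-fold higher number from compound 1 to compound 4 (0.10 log units; within the scatter) and remains a tentative expectation. For compound 4 the estimated half-life is 0.55 h with an expected range from 0.28 h to 1.1 h in this measurement.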

Compound 4, half-life: 0.657 h
Compound 4: middle estimate off by 1.2-fold (0.08 log units), on the low side; low and high end bracket the measured number.
By their numbers in this assay, from the lowest: compounds 1, 3, 4 and 2 (each within the scatter of the next).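

For the compounds shown here, the pair of compound 1 and compound 4 gives the first direct reading of a single change in this assay: on a saturated chain carbon bound to two aromatic carbons, 2,2,2-trifluoro-1-hydroxyethyl in place of dicyanomethyl gives a 1.5-fold higher number from compound 1 to compound 4 (0.18 log units; within the scatter). At this place, then, a group with two triple bonds and no hydrogen-bond donor can give way to a fluorinated group with a hydrogen-bond donor while the half-life stays within the usual scatter. No measurement at hand accounts for this result.

The compounds shown leave open whether a different group at the same place, such as an amine or a carboxylic acid, would move the half-life beyond the scatter. They also leave open how a trifluoromethyl group alone or a hydroxyl group alone would compare there with the full 2,2,2-trifluoro-1-hydroxyethyl group.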